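The source may hold more compounds than are shown below. What is called first, only, known or untested is meant among the compounds shown, and "the series" means these compounds.

Compound 1 `COc1cccc(OC)c1OCCNCCOc1ccccc1OCc1ccccc1C` and compound 2 `COc1cccc(OC)c1OCCNCCOc1ccccc1OCc1cccc(C)c1` share one core and differ only in the ring carried on the saturated chain carbon bound to an oxygen on an aromatic ring. In a functional assay on PC-3 cells (Homo sapiens) for cytotoxicity, read by sulforhodamine B assay (a lower number here means a stronger inhibitor of growth, a higher number a weaker inhibitor of growth), compound 1 gives 33900 nM and compound 2 gives 32300 nM, so the two lie within the scatter of each other; the step of a 1.0-fold lower number from compound 1 to compound 2 (0.02 log units; within the scatter) confirms this. Compound 3 `COc1cccc(OC)c1OCCNCCOc1ccccc1OCc1ccc(OC(C)C)cc1` departs from compound 1 by 4-isopropoxyphenyl in place of 2-methylphenyl on a saturated chain carbon bound to an oxygen on an aromatic ring. Within the data shown here, only the step from compound 1 to compound 2 bears on this, and it was flat, so no step beyond the scatter is expected: compound 3 is estimated at 30000 nM (range 12000 nM to 75000 nM), a step of a 1.1-fold lower number from compound 1 to compound 3 (0.05 log units; within the scatter).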

Compound 3, concentration for total growth inhibition: 17800 nM
Compound 3: the middle estimate sits 1.7-fold (0.23 log units) above what was measured, and the stated range covers the measured number.
By their numbers in this assay, from the lowest: compounds 3, 2 and 1 (each within the scatter of the next).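

In this assay, replacing 2-methylphenyl with 4-isopropoxyphenyl, with 10 heavy atoms against 7 and one hydrogen-bond acceptor against none, gives a 1.9-fold lower number from compound 1 to compound 3 (0.28 log units; within the scatter) and, from the 3-methylphenyl compound, a 1.8-fold lower number from compound 2 to compound 3 (0.26 log units; within the scatter). This position on a saturated chain carbon bound to an oxygen on an aromatic ring has thus taken a larger, oxygen-bearing group, not only a moved methyl, with no step beyond the scatter. Nothing available explains this flatness. Open, as far as these compounds go, is whether an amine or a carboxylic acid on this ring, or a longer chain in place of the benzyl link, would give a step beyond the scatter.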